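A few compounds are considered here, and "the series" means these few. Any claim that something is new, unique, unknown or untested is made for them only; others in the source may bear on it.

Of the compounds shown here, two have been measured in a physicochemical assay for solubility, in phosphate buffer, at pH 7.4 (a lower number here means a less soluble compound, a higher number a more soluble compound), so far. Compound 1 `CC(=O)N[C@@H]1CCC[C@H](C(=O)Nc2cc(-c3cnc(C)n3C(C)C)ccn2)C1` gives 660000 nM in this assay, and compound 2 `CC(=O)N[C@@H]1CCC[C@H](C(=O)Nc2cc(-c3cnc4n3CCCC4)c(Cl)cn2)C1` gives 600000 nM in this assay. Compound 2 has the lower of the two numbers, but the gap to compound 1 is small and lies within the usual scatter, so the two compounds cannot be told apart on solubility. Compound 3 `CC(=O)N[C@@H]1CCC[C@H](C(=O)Nc2cc(-c3cnn4c3COCC4)c(Cl)cn2)C1` has not yet been measured. It differs from compound 2 in one place: a group of 9 heavy atoms (6 carbon, 2 nitrogen, 1 oxygen; one five-membered aromatic ring with 2 hetero atoms, one six-membered non-aromatic ring with 2 hetero atoms) in place of a group of 9 heavy atoms (7 carbon, 2 nitrogen; one five-membered aromatic ring with 2 hetero atoms, one six-membered non-aromatic ring with 1 hetero atom), on an aromatic carbon. Among the compounds with values here, no measured pair shows the effect of such a swap, so there is no step to lean on. With both measured compounds so close together, the expectation for compound 3 is a step of a 1.2-fold higher number from compound 2 to compound 3 (0.07 log units; within the scatter) that stays within the scatter. Compound 3 is therefore estimated at 700000 nM, with a range from 350000 nM to 1400000 nM.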

Compound 3, solubility: 220000 nM
Compound 3: middle estimate off by 3.2-fold (0.50 log units), on the high side; the whole stated range lies above it.
By their numbers in this assay, from the lowest: compound 3; then compounds 2 and 1 (each within the scatter of the next).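

In this assay, replacing one group with the other on the aromatic carbon opposite the ring nitrogen gives a 2.7-fold lower number from compound 2 to compound 3 (0.44 log units; beyond the scatter). Within the data shown here, this is the first step that isolates a single change, and it shows that this position can respond to a swap even when the count of heavy atoms stays the same and both groups pair a five-membered aromatic ring with a six-membered non-aromatic ring. No measurement here explains why the number moves.

A single step cannot separate the oxygen in the six-membered non-aromatic ring from the different placing of the nitrogens in the five-membered aromatic ring. It also leaves open how an amine in place of that oxygen would compare, or whether the same swap would give a similar step without the chloro group on the shared core.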